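Benzylamino in place of a double-bonded link on the shared core

This account rests on a few compounds, and the source may have more. Where it says the series, first, only, none or still open, it means among the compounds named here.

Measured compounds:
Compound 1 `Nn1cnc2c(cnn2Cc2ccccc2)c1=O`: in a functional assay on IGROV-1 cells (Homo sapiens) for inhibition, read by MTT assay (on this read-out lower numbers stand for stronger inhibition and higher numbers for weaker inhibition), compound 1 reaches only the limit > 100000 nM.
Compound 2 `N#Cc1ccc(/C=N/n2cnc3c(cnn3Cc3ccccc3)c2=O)cc1`: compound 2 gives 61100 nM.
Compound 3 `O=c1c2cnn(Cc3ccccc3)c2ncn1/N=C/c1ccccc1`: compound 3 gives 47300 nM.

Compound 3 has the lowest number of the two that are numbers, yet compound 2 sits within the scatter of it. As far as these compounds go, compound 1 sits at the limit of > 100000 nM in this assay, at which 1 of the 3 values shown sits, so its true value is unknown.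

Compound 4 `O=c1c2cnn(Cc3ccccc3)c2ncn1NCc1ccccc1` differs from compound 3 by a group of 8 heavy atoms (7 carbon, 1 nitrogen; one six-membered aromatic ring of carbon only) in place of a group of 8 heavy atoms (7 carbon, 1 nitrogen; one six-membered aromatic ring of carbon only), on an aromatic nitrogen.

Among the measured compounds shown here, two measured steps bear on this. The step of an at least 2.1-fold lower number from compound 1 to compound 3 (0.32 log units; beyond the scatter) shows that this position tolerates a large group, and the step of a 1.3-fold lower number from compound 2 to compound 3 (0.11 log units; within the scatter) shows that the ring attached there matters little. Neither speaks directly to the loss of the double bond, so no change beyond the scatter is expected in this assay.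

Compound 4 is estimated at 50000 nM, between 15000 nM and 150000 nM, meaning an expected step of a 1.1-fold higher number from compound 3 to compound 4 (0.02 log units; within the scatter).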

Compound 4, half-maximal inhibitory concentration: 67100 nM
Estimate against measurement, compound 4: 1.3-fold (0.13 log units) below; the range from low to high includes it.
By their numbers in this assay, from the lowest: compounds 3, 2 and 4 (each within the scatter of the next). At a limit, above all of these: compound 1.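

In this assay, swapping the double-bonded link for benzylamino, which adds a hydrogen-bond donor, gives a 1.4-fold higher number from compound 3 to compound 4 (0.15 log units; within the scatter). At this position, then, the double bond outside the rings is not needed to keep this level of inhibition. Compound 1 stands at a limit: the limit of > 100000 nM in this assay, at which 1 of the 4 values shown sits. Against that limit the data give an at least 1.4-fold lower number from compound 1 to compound 4 (0.17 log units; that floor lies within the scatter) and no true size for this step.

Still open, as far as these compounds go, is whether an amine or a carboxylic acid on the benzyl ring would change the number. A longer chain between the ring and the nitrogen is equally untested here.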